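This account rests on a few compounds, and the source may have more. Where it says the series, first, only, none or still open, it means among the compounds named here.

Compound 1 `CC(C)C(=O)OCOC(=O)C1=C(S[C@@H]2CN[C@H](C(=O)Nc3cccc(C(=O)OCOC(=O)C(C)C)c3)C2)[C@H](C)[C@@H]2[C@@H]([C@@H](C)O)C(=O)N12`: in an ADME assay for metabolic stability, read by LC-MS, with a stated time of 3 h, at pH 6.5, tested at 50 uM (on this read-out lower numbers stand for a less stable compound and higher numbers for a more stable compound), compound 1 gives > 95%, which is a limit of the assay.
Compound 2 `CCOC(=O)C1=C(S[C@@H]2CN[C@H](C(=O)Nc3cccc(C(=O)OCC)c3)C2)[C@H](C)[C@@H]2[C@@H]([C@@H](C)O)C(=O)N12`: in this assay compound 2 gives > 95%, again a limit.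
Compound 3 `CCOC(=O)c1cccc(NC(=O)[C@@H]2C[C@H](SC3=C(C(=O)O)N4C(=O)[C@H]([C@@H](C)O)[C@H]4[C@H]3C)CN2)c1`: in this assay compound 3 gives > 95%, also a limit.

Compound 3 therefore stands at the top of what this assay can report, with no exact number known. For the measured compounds named here, the only single-point step among the measured compounds, a step that the two limits leave unreadable from compound 2 to compound 3, is unreadable for the same reason. Compound 4 `CC(C)C(=O)OCOC(=O)c1cccc(NC(=O)[C@@H]2C[C@H](SC3=C(C(=O)O)N4C(=O)[C@H]([C@@H](C)O)[C@H]4[C@H]3C)CN2)c1` differs from compound 3 by (isopropylcarbonyl)oxy in place of methyl on a saturated chain carbon bound to an oxygen next to a carbonyl group. Going by the values given here, no measured step covers this change directly; what can be said is that every value shown sits at the same limit (the limit of > 95% in this assay, at which 3 of the 3 values shown sit), including compound 1, which carries this group twice. Compound 4 is thus expected to show no step beyond the scatter, a step that the limit leaves unreadable from compound 3 to compound 4. Compound 4 is estimated at 97%, within 88% to 100%.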

Compound 4, percent of the compound remaining: > 95%
Compound 4: no number, only a limit; the forecaster's own chance of this, stated with the estimate: 85%; the middle value lies beyond the limit too.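

No step can be read from compound 3 to compound 4 or from compound 1 to compound 4, because both compounds of each pair sit at the same limit: the limit of > 95% in this assay, at which 4 of the 4 values shown sit.
The compounds shown leave open whether any of these changes alters the true result in this assay.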